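Cytotoxicity notes on a triazole amide pair and a new analogue

A few compounds are considered here, and "the series" means these few. Any claim that something is new, unique, unknown or untested is made for them only; others in the source may bear on it.

- compound 1 `O=C(CCCCCCn1cc(-c2cccnc2)nn1)Nc1ccccc1-c1ccccc1`: 26.2%
- compound 2 `O=C(CCCCCCCCn1cc(-c2cccnc2)nn1)Nc1ccccc1-c1ccccc1`: 13%

Two compounds of this series have been run in a functional assay on SH-SY5Y cells (Homo sapiens) for cytotoxicity, tested at 1 uM; a higher number here means a weaker effect of the compound at the concentration tested, a lower number a stronger effect. Compound 1 gives 26.2%. Compound 2 gives 13%, the lower of the two numbers, and the gap to compound 1 lies beyond the scatter of repeat measurements. Nothing further can be said of that pair here.

Compound 3 `O=C(CCCCCCCCn1cc(-c2cccnc2)nn1)Nc1ccccc1Oc1ccccc1` is the next analogue and has not yet been run in this assay. Relative to compound 2 the change is phenoxy in place of phenyl on an aromatic carbon. The triazole, the chain and the amide are kept; only the group ortho to the amide on the aromatic ring is exchanged.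

Within the data shown here, no measured pair in the set carries a comparable exchange, so there is no precedent for the size of the step. The expectation is therefore a step of a number 5 percentage points higher from compound 2 to compound 3 (within the scatter), small and of no firm direction, most likely within the scatter. Compound 3 is estimated to give 18% in this assay, with a range from 4% to 40%.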

Compound 3, a percentage reported as activity, at one concentration (the size of the read-out at that concentration, not a potency): 22.6%
Estimate against measurement, compound 3: 4.6 percentage points below; the measured number falls inside the stated range.
By their numbers in this assay, from the lowest: compounds 2, 3 and 1 (each within the scatter of the next, the first and the last beyond it).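

Phenoxy in place of phenyl, on an aromatic carbon ortho to a large group, gives a number 9.6 percentage points higher from compound 2 to compound 3 (within the scatter) in this assay, so this exchange does not separate the two compounds in this read-out. Among these compounds, this is the first reading of a change at this position, since compound 1 and compound 2 both carry phenyl there, and it shows that the oxygen and the hydrogen-bond acceptor entering with phenoxy leave the number indistinguishable from that of compound 2. Nothing measured here bears on why the exchange has so little effect on the number.

As far as these compounds go, whether the step stays this small for a different kind of group at this position, such as an amine, a carboxylic acid or a benzyloxy group, remains open. Also open, from the compounds shown here alone, is whether compound 2 and compound 3 would stay indistinguishable at other concentrations, since this assay reports the size of the read-out at one concentration and gives no potency.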